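Fluoro in place of nitro on compound 2

The source may report more compounds than this note shows. Statements on the series, on what has been measured and on what is new or still open speak of the compounds shown alone.

Measured in a functional assay on HBL-100 cells (Homo sapiens) for antiproliferative activity, read by luminescence and CellTiter-Glo, with a stated time of 48 h; on this read-out lower numbers stand for stronger inhibition and higher numbers for weaker inhibition:
Compound 1 `COc1ccc(/C=C/[C@H]2CC=CC(=O)O2)cc1` > 100000 nM (a limit)
Compound 2 `O=C1C=CC[C@H](/C=C/c2ccc([N+](=O)[O-])cc2)O1` 6700 nM
Compound 3 `O=C1C=CC[C@@H](/C=C/c2ccc([N+](=O)[O-])cc2)O1` > 100000 nM (a limit)

Compound 2 alone has a number rather than a limit. Compound 4 `O=C1C=CC[C@H](/C=C/c2ccc(F)cc2)O1` differs from it by fluoro in place of nitro on an aromatic carbon. The nearest evidence is an at least 14-fold lower number from compound 1 to compound 2 (1.17 log units; beyond the scatter), a large step in which nitro replaced methoxy. Compound 4 keeps the configuration of compound 2, so an at least 14-fold higher number from compound 2 to compound 3 (1.17 log units; beyond the scatter), a large step tied to the fact that compounds 2 and 3 differ only in the configuration as drawn, applies only in that respect. With nitro gone, a weaker result is expected, though the size of the loss is uncertain. The expected move is a 3.7-fold higher number from compound 2 to compound 4 (0.57 log units; beyond the scatter). For compound 4 the estimated value is 25000 nM, with an expected range from 7000 nM to 100000 nM.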

Compound 4, half-maximal inhibitory concentration: 14100 nM
Compound 4: the middle estimate sits 1.8-fold (0.25 log units) above what was measured; the range from low to high includes it.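

In this assay, nitro is not essential at this aromatic carbon: fluoro, a single heavy atom, costs only a modest step, a 2.1-fold higher number from compound 2 to compound 4 (0.32 log units; beyond the scatter). Methoxy is the group of the three that stands apart, with an at least 7.0-fold lower number from compound 1 to compound 4 (0.85 log units; beyond the scatter). Compound 1 gives > 100000 nM, which is a limit.

Still open, on these data alone, is how an amine, chloro or a carboxylic acid would read at this aromatic carbon. Also open, as far as these compounds go, is whether fluoro with the configuration of compound 3 would show the same loss as nitro does there.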